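Vinyl in place of ethyl on a saturated chain

The compounds below may be only part of what the source reports. "The series", "measured", "known", "first", "only" and "open" are said of these compounds alone.

Measured in a functional assay on SK-MEL-28 cells (Homo sapiens) for inhibition, read by colorimetric assay and MTT assay, with a stated time of 72 h; a lower number here means a stronger inhibitor, a higher number a weaker inhibitor:
compound 1 `C=CCCCCOc1ccccc1-c1cnc(OCCC=C)n1C`: 17000 nM
compound 2 `C=CCCCCOc1cc2ccccc2cc1-c1cnc(OCCCCC=C)n1C`: 59000 nM
compound 3 `CCCCCCOc1ncc(-c2ccccc2OC)n1C`: 43000 nM

The number for compound 3 lies within the scatter of that for compound 2, and both lie beyond the scatter from the lowest number, that of compound 1.

Compound 4 `C=CCCCCOc1ncc(-c2ccccc2OC)n1C` is still unmeasured. It differs from compound 3 by vinyl in place of ethyl on a saturated chain carbon, four bonds along the chain from an oxygen on an aromatic ring. For the measured compounds named here, no measured pair shows this change alone, so no step beyond the scatter is expected in this assay. The estimated change is a 1.2-fold lower number from compound 3 to compound 4 (0.08 log units; within the scatter). The expected value for compound 4 is 36000 nM, within an estimated range of 17000 nM to 70000 nM.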

Compound 4, half-maximal inhibitory concentration: 13000 nM
The estimate for compound 4 lay 2.8-fold (0.44 log units) above the measured number, and the stated range ends above it.
By their numbers in this assay, from the lowest: compounds 4 and 1 (each within the scatter of the next); then compounds 3 and 2 (each within the scatter of the next).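

Vinyl in place of ethyl on a saturated chain carbon, four bonds along the chain from an oxygen on an aromatic ring, gives in this assay a clean reading of a 3.3-fold lower number from compound 3 to compound 4 (0.52 log units; beyond the scatter). The earlier compounds shown here differ in more than one place and could not isolate this change, which here alone moves the number. Nothing available explains why this change has this effect. The compounds shown leave open whether a step of this size would also appear with an ethynyl group or a longer chain on the same carbon.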